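This account rests on a few compounds, and the source may have more. Where it says the series, first, only, none or still open, it means among the compounds named here.

Three ureas have been measured in an ADME assay on the whole organism with Oryza sativa as the target, tested at 0.1 uM; on this read-out lower numbers stand for a stronger effect and higher numbers for a weaker effect at the one concentration tested. Compound 1 `C[C@H](NC(=O)Nc1ccccc1C(F)(F)F)c1ccccc1` gives 97%. Compound 2 `C[C@H](NC(=O)Nc1ccccc1F)c1ccccc1` gives 98% in this assay. Compound 3 `C[C@@H](NC(=O)Nc1cccc(F)c1F)c1ccccc1` gives 100% in this assay. The gaps between any two of these three values lie within the usual scatter of such measurements, so no order among compound 1, compound 2 and compound 3 can be read from them.

Compound 1 arises from compound 2 by trifluoromethyl in place of fluoro on an aromatic carbon, and this step gives a number 1 percentage points lower from compound 2 to compound 1 (within the scatter). The difference between the core of compound 3 and the core of compound 2 is not broken down here.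

Compound 4 `C[C@@H](NC(=O)Nc1cccc(C(F)(F)F)c1F)c1ccccc1` has not yet been measured. It arises from compound 3 by trifluoromethyl in place of fluoro on an aromatic carbon. For the measured compounds named here, this is the same kind of change as the one from compound 2 to compound 1, but the surroundings differ: in compound 1 the entering group sits ortho to a large group, whereas in compound 4 it sits ortho to a fluoro group and meta to a large group. For compound 4 a step of a number 1 percentage points lower from compound 3 to compound 4 (within the scatter) is expected in this assay. This expectation rests on the step of a number 1 percentage points lower from compound 2 to compound 1 (within the scatter), which stayed within the scatter, and on the closeness of all three measured values to the top of the range. The estimate for compound 4 in this assay is therefore 99%, expected to fall between 91% and 100%.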

Compound 4, a percentage reported as activity, at one concentration (the size of the read-out at that concentration, not a potency): 99%
Estimate against measurement, compound 4: no gap at the digits printed; the range from low to high includes it.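

In this assay, trifluoromethyl in place of fluoro on an aromatic carbon gives a number 1 percentage points lower from compound 3 to compound 4 (within the scatter), where the entering group sits ortho to a fluoro group and meta to a large group. Set beside the earlier step on the other core, the new step does not differ from it: the same change on two cores in this assay, a number 1 percentage points lower (within the scatter) from compound 2 to compound 1 and a number 1 percentage points lower (within the scatter) from compound 3 to compound 4, 0 percentage points apart, within the scatter of two such steps

This shows that, on these two cores, the change left the read-out within the scatter in both cases, so the two results agree; it does not show that the change has any real effect of its own in this assay, since neither step stands clear of the scatter, and agreement between two steps that are both this small says little about how the change would behave on a core where the read-out lies lower in the range.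

The compounds shown leave open what a group other than fluoro or trifluoromethyl on the aromatic ring, such as an amine, a carboxylic acid or a nitrile, would do to the read-out. They also leave open whether a longer chain in place of the methyl group would move the value beyond the scatter, and whether the step would then still carry over.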